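This account rests on a few compounds, and the source may have more. Where it says the series, first, only, none or still open, it means among the compounds named here.

Measured so far:
compound 1 `COc1cc2ncnc(Nc3ccc(N)cc3)c2cc1OC`: "not active" (no number reported) in an assay on isolated protein for inhibition of vascular endothelial growth factor receptor 1 (Homo sapiens), read by ELISA, with a stated time of 20 min, tested at 1 uM; a higher number here means more inhibition at the concentration tested (going by the name of the read-out), a lower number less inhibition
compound 2 `COCCOc1cc2ncnc(Nc3cccc(B(O)O)c3)c2cc1OC`: 19%
compound 3 `COCCOc1cc2ncnc(Nc3ccc(B(O)O)cc3)c2cc1OCCOC`: 41%

Of the two numbers recorded in this assay, compound 3 holds the higher one with 41%; compound 2 sits lower by more than the usual scatter with 19%, and compound 1 is recorded only as "not active" (no number reported).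

Compound 4 `COCCOc1cc2ncnc(Nc3cccc(B(O)O)c3)c2cc1OCCOC` is the next entry. It differs from compound 3 by a group of 9 heavy atoms (6 carbon, 1 boron, 2 oxygen; one six-membered aromatic ring of carbon only) in place of a group of 9 heavy atoms (6 carbon, 1 boron, 2 oxygen; one six-membered aromatic ring of carbon only), on a nitrogen on an aromatic ring. Among the compounds with values here, no step between measured compounds is known, so the size of this move is not fixed by the data. Compound 4 carries on that nitrogen the same arrangement as compound 2, which gives 19%. On that single point, a downward step beyond the scatter is expected, a number 19 percentage points lower from compound 3 to compound 4 (beyond the scatter). Compound 4 is therefore estimated at 22%, within 5% to 42%.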

Compound 4, a percentage reported as inhibition, at one concentration (the size of the read-out at that concentration, not a potency): "not active" (no number reported)
Nothing numeric was reported for compound 4; no gap can be computed for the estimate.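

Within the data shown here, compound 4 gives "not active" (no number reported) and so no step from compound 3 can be read. No other evidence bears on this result. The compounds shown leave open how large the move from compound 3 to compound 4 is.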